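A few compounds are considered here, and "the series" means these few. Any claim that something is new, unique, unknown or untested is made for them only; others in the source may bear on it.

Measured in an assay on CHO cells for displacement of a labelled ligand from melatonin receptor type 1B (Homo sapiens), read by scintillation counting, with a stated time of 60 min; a higher number here means a weaker inhibitor, a lower number a stronger inhibitor:
- compound 1 `COc1cccc(CCCNC(C)=O)c1` gives 0.751 nM
- compound 2 `CCCOc1ccc(OC)cc1CCCNC(C)=O` gives 2.12 nM
- compound 3 `COc1cc(COc2ccc(OC)cc2CCCNC(C)=O)cc(OC)c1` gives 0.0326 nM

Compound 2 carries the highest number of the three in this assay. Going by the values given here, its nearest neighbour is compound 1, the only step to it being a 2.8-fold higher number from compound 1 to compound 2 (0.45 log units; beyond the scatter); compound 3 lies furthest away, with a much lower number than compound 2.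

Compound 4 `COc1ccc(OCc2ccccn2)c(CCCNC(C)=O)c1` is not yet measured. It is derived from compound 2 by the change (pyridin-2-yl in place of ethyl on a saturated chain carbon bound to an oxygen on an aromatic ring). Among the compounds with values here, no measured step bears directly on this change. Within the data shown here, the only measured step, from compound 1 to compound 2, concerns the introduction of the propoxy group itself, not its elaboration. The pair compound 2 and compound 3 shows that exchanging the propyl for a benzyl-type group bearing an aromatic ring goes with a far lower number, though that pair differs in more than this one place and is not a counted step. On that basis a lower number is expected for compound 4 in this assay, as a step of an 8.5-fold lower number from compound 2 to compound 4 (0.93 log units; beyond the scatter). The estimate for compound 4 is 0.25 nM, with a range from 0.04 nM to 1.5 nM.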

Compound 4, inhibition constant: 1.61 nM
For compound 4 the middle estimate is 6.4-fold (0.81 log units) below the measured one; measured number outside the range, above it.
By their numbers in this assay, from the lowest: compound 3; then compound 1; then compounds 4 and 2 (each within the scatter of the next).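

In this assay, pyridin-2-yl in place of ethyl gives numbers that stay within the scatter (a 1.3-fold lower number from compound 2 to compound 4 (0.12 log units; within the scatter)). This place, on a saturated chain carbon bound to an oxygen on an aromatic ring, therefore accepts the larger group with its six-membered aromatic ring and hydrogen-bond acceptor, with no measurable difference from the propyl compound. An aromatic ring here is also not enough on its own to reach the value of the dimethoxy-substituted compound: compound 4 gives 1.61 nM and compound 3 gives 0.0326 nM; no evidence at hand accounts for this result.

Open, from the compounds shown here alone, is whether the two methoxy groups of compound 3 or its all-carbon ring carry that difference. An unsubstituted phenyl, or a pyridine ring bearing methoxy groups, on the same chain carbon would separate the two.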